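Carboxylic acid to carbamate on the aryl tail

The source may report more compounds than this note shows. Statements on the series, on what has been measured and on what is new or still open speak of the compounds shown alone.

Compound 1 `O=C(O)c1ccc(CCCCCCC(=O)c2ncc(-c3ccccn3)o2)cc1`: > 600 nM
Compound 2 `O=C(CCCCCCc1cccc(Cl)c1Cl)c1ncc(-c2ccccn2)o1`: 0.9 nM

The two measured compounds share one core and differ only in the aryl group on a saturated chain carbon, six bonds along the chain from the carbonyl carbon. In an assay for inhibition of Fatty-acid amide hydrolase 1 (Rattus norvegicus) (a lower number here means a stronger inhibitor, a higher number a weaker inhibitor), compound 1 gives only a limit, > 600 nM, and no number. For the measured compounds named here, the single measured step is an at least 660-fold lower number from compound 1 to compound 2 (2.82 log units; beyond the scatter). Compound 1 thus stands at the limit of > 600 nM in this assay, at which 1 of the 2 values shown sits, the weaker end of what is known here.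

Compound 3 `CC(C)(C)OC(=O)Nc1ccc(CCCCCCC(=O)c2ncc(-c3ccccn3)o2)cc1` carries (tert-butoxycarbonyl)amino in place of carboxy on an aromatic carbon. Going by the values given here, only the step of an at least 660-fold lower number from compound 1 to compound 2 (2.82 log units; beyond the scatter) bears on this change; it shows that taking away the carboxyphenyl group gives a much lower number, but it says nothing direct about a carbamate in the same place. Compound 1 is known only as a limit, so the size of the step to compound 3 in this assay can be set only loosely. A lower number is expected, estimated as an at least 20-fold lower number from compound 1 to compound 3 (1.30 log units; beyond the scatter). For compound 3 the estimate in this assay is 30 nM, with an expected range from 3 nM to 300 nM.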

Compound 3, inhibition constant: 5.6 nM
The estimate for compound 3 lay 5.4-fold (0.73 log units) above the measured number, within the range that was stated.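

In this assay, keeping the aryl ring and changing only the group on its aromatic carbon, para to a large group, gives an at least 100-fold lower number from compound 1 to compound 3 (2.02 log units; beyond the scatter). The earlier step replaced the whole 4-carboxyphenyl group, so it could not separate the carboxy group from the ring that carries it. Here the ring stays and the number still falls, which ties the large change to the swap of carboxy for (tert-butoxycarbonyl)amino at this place, although the value for compound 1 remains a limit: the limit of > 600 nM in this assay, at which 1 of the 3 values shown sits.

The compounds shown leave open whether the whole carbamate is needed, or whether a free amine, an acetamide or a methyl ester on the same aromatic carbon would give a similarly low number in this assay. They also leave open how a shorter or longer saturated chain would act with the (tert-butoxycarbonyl)amino group in place, and whether a carboxylic acid carried on a longer chain would remain as weak as the limit for compound 1 suggests.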